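Removing the nitro from a carbamate-selenocyanate

The source may report more compounds than this note shows. Statements on the series, on what has been measured and on what is new or still open speak of the compounds shown alone.

Measured compounds:
compound 1, `CCCCOC(=O)Nc1ccc([Se]C#N)cc1` — 20200 nM in a functional assay on MCF7 cells (Homo sapiens) for cytotoxicity, read by MTT assay, with a stated time of 72 h; a higher number here means a weaker inhibitor of growth, a lower number a stronger inhibitor of growth
compound 2, `N#C[Se]c1ccc(NC(=O)OCc2ccc([N+](=O)[O-])cc2)cc1` — 40700 nM in this assay

Two para-selenocyanato anilides bearing a carbamate were examined in this assay. Compound 1 gives 20200 nM. Compound 2 gives 40700 nM; its number is the top of the two, but its distance from compound 1 is within the scatter, so the two compounds cannot be told apart on these data.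

Compound 3, `N#C[Se]c1ccc(NC(=O)OCc2ccccc2)cc1`, has yet to be tested in this assay. It differs from compound 2 by hydrogen in place of nitro on an aromatic carbon. Within the data shown here, no comparable step between measured compounds exists here, so the expectation rests on the two values alone, which sit close together. Compound 3 is therefore expected to land near compound 2, with an estimated step of a 1.5-fold lower number from compound 2 to compound 3 (0.16 log units; within the scatter) that should stay within the scatter. The estimate for compound 3 is 28000 nM, ranging from 9000 nM to 90000 nM.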

Compound 3, concentration for total growth inhibition: 38800 nM
Beside the measured number, compound 3's estimate is 1.4-fold (0.14 log units) below it; the measured number falls inside the stated range.
By their numbers in this assay, from the lowest: compounds 1, 3 and 2 (each within the scatter of the next).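

In this assay, on this aromatic carbon, para to a large group, hydrogen in place of nitro gives a 1.0-fold lower number from compound 2 to compound 3 (0.02 log units; within the scatter), so on these data the nitro group can be exchanged for hydrogen with no change that can be read. Phenyl in place of propyl on a saturated chain carbon bound to an oxygen next to a carbonyl group gives a 1.9-fold higher number from compound 1 to compound 3 (0.28 log units; within the scatter), so this change at the other end of the carbamate cannot be told from no change either. Nothing measured here speaks to why the numbers sit where they do.

The compounds shown leave open whether an amine or a methoxy group on the same aromatic carbon, or a longer chain in place of the propyl, would move the number beyond the scatter. They also leave open whether any change to the carbamate matters in this assay, since every step read so far lies within the scatter.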